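Permeability Outlook for a Benzyl Replacement on the Shared Core

The source may hold more compounds than are shown below. What is called first, only, known or untested is meant among the compounds shown, and "the series" means these compounds.

Compound 1 `COc1cccc(CNCCCNc2ccnc3cc(Oc4ccc(F)cc4)ccc23)c1O`: in an ADME assay for permeability, using PAMPA, with a stated time of 30 min, at pH 7.4 (a lower number here means that the compound crosses the layer more slowly, a higher number that the compound crosses the layer faster), compound 1 gives 317 10^-6 cm/s.
Compound 2 `COc1cccc(CNCCCNc2ccnc3cc(Oc4ccc(C(C)(C)C)cc4)ccc23)c1O`: in this assay compound 2 gives 317 10^-6 cm/s.

On these numbers compound 2 stands level with compound 1 at the digits shown. Among the measured compounds shown here, the only measured step, no change at the digits printed from compound 1 to compound 2 (within the scatter), lies within the scatter, so the two compounds cannot be ordered.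

Compound 3 `COc1cccc(CNCCCNc2ccnc3cc(Cc4ccc(F)cc4Cl)ccc23)c1O` has not yet been measured in this assay. It differs from compound 2 in one place: 2-chloro-4-fluorobenzyl in place of 4-(tert-butyl)phenoxy on an aromatic carbon. For the measured compounds named here, the one measured step bears on this only loosely, since it swapped a group on an aromatic carbon and left the apparent permeability unchanged, while the change to compound 3 swaps a larger part. Going by the values given here, no measured step shows a move beyond the scatter, and nothing here points in either direction.

For compound 3 the expected step is no change at the digits printed from compound 2 to compound 3 (within the scatter), that is no change beyond the scatter. Compound 3 is therefore estimated at about 317 10^-6 cm/s, with a range from 150 10^-6 cm/s to 650 10^-6 cm/s.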

Compound 3, apparent permeability: 23 10^-6 cm/s
For compound 3 the middle estimate is 14-fold (1.14 log units) above the measured one, outside the stated range (below it).
By their numbers in this assay, from the lowest: compound 3; then compounds 1 and 2 (each within the scatter of the next).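

In this assay, this position on the shared core is not indifferent to what it carries: the change to 2-chloro-4-fluorobenzyl brings a 14-fold lower number from compound 2 to compound 3 (1.14 log units; beyond the scatter), and the same group in place of 4-fluorophenoxy brings a 14-fold lower number from compound 1 to compound 3 (1.14 log units; beyond the scatter). Both phenoxy compounds thus lead to the same large step, although exchanging the fluoro for tert-butyl on the phenoxy ring had produced no change at the digits printed from compound 1 to compound 2 (within the scatter), so the position tolerated that swap but not the replacement of the whole group. Nothing available explains this fall.

The change replaces the phenoxy oxygen and alters the ring substituents in a single step, so the compounds shown cannot say which of these goes with the fall. An unsubstituted benzyl or a 2-chloro-4-fluorophenoxy group on the same carbon would separate the two.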